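Swapping Fluorines for Chlorines on the Sulfonyl-Bound Ring

The source may report more compounds than this note shows. Statements on the series, on what has been measured and on what is new or still open speak of the compounds shown alone.

Going by the values given here, compound 2 `O=S(=O)(c1ccc(F)c(F)c1)c1cnc2c(F)cccc2c1-c1cccc(F)c1` holds the lowest of the two numbers so far in an ADME assay on microsomes from liver (Homo sapiens) for metabolic stability, tested at 2.5 uM; a lower number here means slower removal, a higher number faster removal of the compound: compound 2 gives 1.28 mL/min, while compound 1 `COc1ccc(S(=O)(=O)c2cnc3c(F)cccc3c2-c2cccc(F)c2)cc1` gives 3.03 mL/min. Among the compounds with values here, the only measured step, a 2.4-fold lower number from compound 1 to compound 2 (0.37 log units; beyond the scatter), altered the same sulfonyl-bound ring. Compound 3 `O=S(=O)(c1cc(Cl)cc(Cl)c1)c1cnc2c(F)cccc2c1-c1cccc(F)c1` differs from compound 2 by 3,5-dichlorophenyl in place of 3,4-difluorophenyl on a sulfonyl sulfur. That earlier step bears only loosely on this change, which keeps two halogens on the ring, so no shift beyond the scatter is expected, the estimated step being a 1.2-fold higher number from compound 2 to compound 3 (0.07 log units; within the scatter). Compound 3 is therefore expected to give about 1.5 mL/min, within 0.6 mL/min to 3.5 mL/min.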

Compound 3, intrinsic clearance in a liver preparation (reported as CLH), per the amount of preparation that the assay uses: 1.08 mL/min
Compound 3: the middle estimate sits 1.4-fold (0.14 log units) above what was measured; the measured number falls inside the stated range.
By their numbers in this assay, from the lowest: compounds 3 and 2 (each within the scatter of the next); then compound 1.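

In this assay, 3,5-dichlorophenyl and 3,4-difluorophenyl on the sulfonyl sulfur cannot be told apart, with a 1.2-fold lower number from compound 2 to compound 3 (0.07 log units; within the scatter) between them, so this swap of halogens and their ring positions leaves the number unresolved from before. Compared with 4-methoxyphenyl, the new ring gives a 2.8-fold lower number from compound 1 to compound 3 (0.45 log units; beyond the scatter) and thus, like 3,4-difluorophenyl, stands clear of compound 1. Nothing available explains this likeness. From the compounds shown here alone, whether an unsubstituted phenyl ring or an amine on the sulfonyl sulfur would keep the number this low remains open.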